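A Methyl Added to Compound 3

A few compounds are considered here, and "the series" means these few. Any claim that something is new, unique, unknown or untested is made for them only; others in the source may bear on it.

Measured in a functional assay for inhibition, with Homo sapiens as the target; on this read-out lower numbers stand for tighter binding and higher numbers for weaker binding:
- Compound 1 `N#Cc1ccccc1C1OCC(C/C=C\CCC(=O)O)C(c2cccnc2)O1`: 245 nM
- Compound 2 `O=C(O)CC/C=C\CC1COC(c2cccs2)OC1c1cccnc1`: 1000 nM
- Compound 3 `CC(C)(Oc1ccccc1)C1OCC(C/C=C\CCC(=O)O)C(c2cccnc2)O1`: 75.9 nM

Of these three, compound 3 has the lowest number, and its gap to each of the others lies beyond the scatter. The nearer of the two is a modest 3.2-fold lower number from compound 1 to compound 3 (0.51 log units; beyond the scatter), and the other is a large 13-fold lower number from compound 2 to compound 3 (1.12 log units; beyond the scatter).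

Compound 4 `Cc1ccc(OC(C)(C)C2OCC(C/C=C\CCC(=O)O)C(c3cccnc3)O2)cc1` has not yet been measured in this assay. It differs from compound 3 by one small change: methyl in place of hydrogen on an aromatic carbon. In words, methyl takes the place of hydrogen on an aromatic carbon, turning phenoxy into 4-methylphenoxy.

Among the compounds with values here, no measured step tests this change directly. The closest evidence is a 3.2-fold lower number from compound 1 to compound 3 (0.51 log units; beyond the scatter) and a 13-fold lower number from compound 2 to compound 3 (1.12 log units; beyond the scatter), but each of those replaces a whole group on a saturated ring carbon, whereas compound 4 keeps the group of compound 3 and adds only a methyl. The data therefore give no direction, and only a small change is expected. The expected step is a 1.1-fold lower number from compound 3 to compound 4 (0.04 log units; within the scatter), and a shift beyond the scatter is not anticipated. For compound 4 the estimated value is 70 nM, with an expected range of 30 nM to 165 nM.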

Compound 4, dissociation constant: 631 nM
Compound 4: the middle estimate sits 9.0-fold (0.95 log units) below what was measured; measured number outside the range, above it.
By their numbers in this assay, from the lowest: compound 3; then compound 1; then compounds 4 and 2 (each within the scatter of the next).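

Up to this point the compounds had differed only by a whole group on a saturated ring carbon. Here that group stays in place, and a single methyl on an aromatic carbon, para to a large group, gives an 8.3-fold higher number from compound 3 to compound 4 (0.92 log units; beyond the scatter) in this assay. This aromatic carbon is therefore far from indifferent to substitution, since turning phenoxy into 4-methylphenoxy moves the number further, in the opposite direction, than the whole-group replacement behind a 3.2-fold lower number from compound 1 to compound 3 (0.51 log units; beyond the scatter). Nothing measured here accounts for this step.

The compounds shown carry only hydrogen or methyl at this carbon, so it stays open whether a fluorine atom, a methoxy group or a longer chain there would raise the number in the same way, or whether some group would keep it near the value of compound 3, 75.9 nM. Whether a methyl on the aromatic ring of compound 1 would shift the number as it does here also stays open, as the only pair of this kind shown is the one built on phenoxy.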